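This account rests on a few compounds, and the source may have more. Where it says the series, first, only, none or still open, it means among the compounds named here.

Compound 1 `COc1ccc(N(C)c2nc(C)nc3ccccc23)cc1C(=O)OCCC[Se]C#N`: 1140 nM
Compound 2 `COc1ccc(N(C)c2nc(C)nc3ccccc23)cc1C(=O)NCC[Se]C#N`: 1170 nM
Compound 3 `COc1ccc(N(C)c2nc(C)nc3ccccc23)cc1C(=O)OCCCCCC[Se]C#N`: 1990 nM
Compound 4 `COc1ccc(N(C)c2nc(C)nc3ccccc23)cc1C(=O)OCCCCC[Se]C#N`: not yet measured

All three values come from a functional assay on RKO cells (Homo sapiens) for inhibition, read by MTT assay, with a stated time of 48 h; on this read-out higher numbers stand for weaker inhibition and lower numbers for stronger inhibition. Compound 3 stands level with the other two once the usual scatter is allowed for, as a 1.7-fold higher number from compound 1 to compound 3 (0.24 log units; within the scatter) and a 1.7-fold higher number from compound 2 to compound 3 (0.23 log units; within the scatter) show.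

Going to compound 4 is a group of 3 heavy atoms (1 carbon, 1 nitrogen, 1 selenium; no ring) in place of a group of 4 heavy atoms (2 carbon, 1 nitrogen, 1 selenium; no ring), on a saturated chain carbon, five bonds along the chain from an oxygen next to a carbonyl group. The ester stays and the chain gets shorter, although it remains longer than the chain of compound 1. Among the compounds with values here, the most relevant evidence is the one measured step that changes only chain length, a 1.7-fold higher number from compound 1 to compound 3 (0.24 log units; within the scatter). The ester-to-amide step, a 1.0-fold higher number from compound 1 to compound 2 (0.01 log units; within the scatter), bears on it less, since it also alters the link to the carbonyl carbon. Neither step leaves the scatter, so no shift beyond the scatter is expected in this assay, and no firm direction can be claimed. The expected change is a 1.3-fold lower number from compound 3 to compound 4 (0.12 log units; within the scatter). Compound 4 is estimated at 1500 nM, with an expected range of 800 nM to 2800 nM.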

Compound 4, half-maximal inhibitory concentration: 356 nM
Compound 4: the middle estimate sits 4.2-fold (0.62 log units) above what was measured, and the stated range ends above it.
By their numbers in this assay, from the lowest: compound 4; then compounds 1, 2 and 3 (each within the scatter of the next).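

In this assay, within the data shown here, shortening the chain at this saturated chain carbon, five bonds along the chain from an oxygen next to a carbonyl group, gives a 5.6-fold lower number from compound 3 to compound 4 (0.75 log units; beyond the scatter) and is the first change here to leave the scatter. The gap also holds against the other two compounds, with a 3.2-fold lower number from compound 1 to compound 4 (0.51 log units; beyond the scatter) and a 3.3-fold lower number from compound 2 to compound 4 (0.52 log units; beyond the scatter) as the steps, so among the three esters the number does not follow chain length in one direction: compound 4, with the intermediate chain, is the most potent, while compound 1 and compound 3, with the shortest and longest chains, stand level. Nothing available here explains why this chain length stands apart.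

Still open, on these data alone, is whether a chain of a length between those of compound 1 and compound 4 would keep this low number. Also open, as far as these compounds go, is whether an amide link carrying the chain of compound 4, or a sulfur atom in place of the selenium, would do the same.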